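This account rests on a few compounds, and the source may have more. Where it says the series, first, only, none or still open, it means among the compounds named here.

Measured so far:
Compound 1 `CN(C)CCN(CCN(C)C)c1cccc(C(=O)N2CCc3ccc(OS(N)(=O)=O)cc3C2)c1` in an assay on HEK293 cells for inhibition of Steryl-sulfatase (Homo sapiens), tested at 1 uM (on this read-out higher numbers stand for a stronger effect at the one concentration tested and lower numbers for a weaker effect), gives 17.1%.
Compound 2 `CCN(Cc1cccc(Br)c1)c1cccc(C(=O)N2CCc3ccc(OS(N)(=O)=O)cc3C2)c1` in this assay gives 24.9%.

Within the data shown here, compound 2 stands within the scatter of compound 1; the only measured step, a number 7.8 percentage points higher from compound 1 to compound 2 (within the scatter), is within the scatter. Compound 3 `CC(C)CCN(CCC(C)C)c1cccc(C(=O)N2CCc3ccc(OS(N)(=O)=O)cc3C2)c1` differs from compound 2 by diisopentylamino in place of (3-bromobenzyl)(ethyl)amino on an aromatic carbon. Among the measured compounds shown here, the one step that bears on this place is the exchange of the group on the same aromatic carbon, and it was within the scatter, so no step beyond the scatter is expected in this assay for compound 3; the expected step is a number 3.9 percentage points lower from compound 2 to compound 3 (within the scatter). Compound 3 is estimated at 21%, with a range from 6% to 38%.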

Compound 3, a percentage reported as inhibition, at one concentration (the size of the read-out at that concentration, not a potency): 75.9%
Compound 3: the middle estimate sits 54.9 percentage points below what was measured; measured number above the stated range.
By their numbers in this assay, from the lowest: compounds 1 and 2 (each within the scatter of the next); then compound 3.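

At this aromatic carbon the choice of amino group does matter in this assay, with a number 51 percentage points higher from compound 2 to compound 3 (beyond the scatter) and a number 58.8 percentage points higher from compound 1 to compound 3 (beyond the scatter), whereas the earlier exchange stayed within the scatter. Diisopentylamino and (3-bromobenzyl)(ethyl)amino have the same counts of heavy atoms, donors and acceptors and no net charge, so those counts do not separate compound 2 from compound 3, though the ring and bromine leave with the exchange. Nothing available accounts for the gain. Open, from the compounds shown here alone, is whether both isopentyl chains are needed: ethyl(isopentyl)amino would test one chain, and dibutylamino would test unbranched chains.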